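Swapping an Amino Side Chain for a Pyridine Ring

The source may report more compounds than this note shows. Statements on the series, on what has been measured and on what is new or still open speak of the compounds shown alone.

Measured compounds:
- compound 1, `Nc1nc(Nc2ccc(OC(F)(F)F)cc2)c2nc[nH]c2n1`: 20000 nM
- compound 2, `C=C1NNC(=O)N=C1Nc1ccc2cn[nH]c2c1`: 16000 nM
- compound 3, `Cc1[nH]c2ccccc2c1-c1ccnc(NC(CO)C(C)C)n1`: 50000 nM

Of the compounds shown here, three have been tested in an assay on isolated protein for inhibition of interferon-induced, double-stranded RNA-activated protein kinase (Homo sapiens), read by luminescence, with a stated time of 10 min; a higher number here means a weaker inhibitor, a lower number a stronger inhibitor. In this assay compound 1 gives 20000 nM, compound 2 gives 16000 nM and compound 3 gives 50000 nM. Compound 3 stands at the highest number of the three, and its distance to each of the other two lies beyond the scatter of the method, so it is the weakest inhibitor measured here. Compound 1 is its nearest neighbour and compound 2 the furthest.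

The next compound, compound 4 (`Cc1[nH]c2ccccc2c1-c1ccnc(Nc2cccnc2)n1`), keeps the core of compound 3 and differs in one place: pyridin-3-yl in place of 1-(hydroxymethyl)-2-methylpropyl on a nitrogen on an aromatic ring. The hydroxy-bearing branched chain is gone, and a second aromatic ring hangs from the same nitrogen instead.

Among the compounds with values here, no measured pair shows this change, so its effect is unknown. The expectation is a small step downward in this assay, about the size of the usual scatter, as a 2.0-fold lower number from compound 3 to compound 4 (0.30 log units; within the scatter). Compound 4 is therefore estimated at 25000 nM, with a range from 8000 nM to 80000 nM.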

Compound 4, half-maximal inhibitory concentration: 100 nM
The estimate for compound 4 lay 250-fold (2.40 log units) above the measured number; the whole stated range lies above it.
By their numbers in this assay, from the lowest: compound 4; then compounds 2 and 1 (each within the scatter of the next); then compound 3.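

In this assay, the group on this nitrogen on an aromatic ring has a very strong influence on the number: placing pyridin-3-yl where 1-(hydroxymethyl)-2-methylpropyl stood gives a 500-fold lower number from compound 3 to compound 4 (2.70 log units; beyond the scatter), with the rest of the molecule unchanged. The two groups have the same count of heavy atoms and each has a hydrogen-bond acceptor, so the step does not come with a change in that count; what does change is that an open chain gives way to a six-membered aromatic ring, a hydrogen-bond donor is lost, and an oxygen is exchanged for a ring nitrogen. No supporting measurement singles out which of these differences matters for the step.

The compounds shown leave open whether the aromatic ring alone is enough or its ring nitrogen is needed as well, a question that a plain phenyl group on the same nitrogen would address. They also leave open whether a saturated cyclohexyl ring or a simple isobutyl chain without the hydroxyl would keep the number high or bring it down.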